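Changing the Group on the Sulfonyl Sulfur

The compounds below may be only part of what the source reports. "The series", "measured", "known", "first", "only" and "open" are said of these compounds alone.

Of the compounds shown here, two have been measured in an assay for inhibition of Nicotinamide phosphoribosyltransferase (Homo sapiens), read by mass spectrometry, with stated times of 15 min and 30 min; a higher number here means a weaker inhibitor, a lower number a stronger inhibitor. Compound 2 `O=C(NCc1ccc(S(=O)(=O)c2cccc(C(F)(F)F)c2)cc1)c1cc2ccncc2o1` gives 5 nM, the lower of the two numbers. Compound 1 `O=C(NCc1ccc(S(=O)(=O)N2CCCCC2)cc1)c1ccn2cncc2c1` gives 1700 nM, a much higher number, beyond the scatter; compound 1 differs from compound 2 both in the core and in the group on the sulfonyl sulfur, so these two numbers alone cannot say which change carries the gap. Compound 3 `O=C(NCc1ccc(S(=O)(=O)N2CCCCC2)cc1)c1cc2ccncc2o1` keeps the core of compound 2 and alters only the sulfonyl substituent: piperidin-1-yl in place of 3-(trifluoromethyl)phenyl on a sulfonyl sulfur. For the measured compounds named here, no measured pair isolates this change. Since compound 1 carries the same piperidin-1-yl group and gives 1700 nM, some loss of potency is expected, though part of that gap may belong to the different core. The step from compound 2 to compound 3 is expected to be a moderate rise, an 8.0-fold higher number from compound 2 to compound 3 (0.90 log units; beyond the scatter). Compound 3 is therefore estimated at 40 nM, within a range from 8 nM to 300 nM.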

Compound 3, half-maximal inhibitory concentration: 40 nM
Compound 3: the middle estimate sits on the measured number at the digits printed, within the range that was stated.
By their numbers in this assay, from the lowest: compound 2; then compound 3; then compound 1.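

The sulfonyl sulfur accepts a non-aromatic ring with only a modest loss in this assay: replacing 3-(trifluoromethyl)phenyl with piperidin-1-yl gives an 8.0-fold higher number from compound 2 to compound 3 (0.90 log units; beyond the scatter). This means the aromatic group is not essential for a number well below that of compound 1. With piperidin-1-yl held fixed, the core change gives a large step, a 43-fold lower number from compound 1 to compound 3 (1.63 log units; beyond the scatter), so the core matters strongly for this series, and the sulfonyl change is the smaller of the two steps. No measurement here explains why either change moves the number.

As far as these compounds go, it remains open whether a plain phenyl ring on the sulfur would behave like 3-(trifluoromethyl)phenyl, or a morpholine ring like piperidin-1-yl. Also open, from the compounds shown here alone, is whether the core step keeps its size when 3-(trifluoromethyl)phenyl stays on the sulfur.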